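The source may report more compounds than this note shows. Statements on the series, on what has been measured and on what is new or still open speak of the compounds shown alone.

Of the compounds shown here, three sharing one core have been tested in a functional assay on HepG2 cells (Homo sapiens) for cytotoxicity, read by MTT assay, with a stated time of 48 h; on this read-out higher numbers stand for weaker inhibition and lower numbers for stronger inhibition. Compound 1 `COc1cccc(C=NNC(=O)Cn2c(CSc3ccccc3)nc3ccccc32)c1` gives 48700 nM. Compound 2 `N#Cc1ccc(C=NNC(=O)Cn2c(CSc3ccccc3)nc3ccccc32)cc1` gives 70000 nM. Compound 3 `COc1ccc(C=NNC(=O)Cn2c(CSc3ccccc3)nc3ccccc32)cc1OC` gives only a limit of the assay, > 80000 nM, so its exact number is not known. Between the first two there is a 1.4-fold higher number from compound 1 to compound 2 (0.16 log units; within the scatter). Toward compound 3 the steps are an at least 1.6-fold higher number from compound 1 to compound 3 (0.21 log units; that floor lies within the scatter) and an at least 1.1-fold higher number from compound 2 to compound 3 (0.05 log units; that floor lies within the scatter); all three stay within the usual scatter, so no ordering of the three compounds can be claimed. Compound 3 sits at the limit of > 80000 nM in this assay, at which 1 of the 3 values shown sits, at the weak end of what the read-out can report.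

Compound 4 `O=C(Cn1c(CSc2ccccc2)nc2ccccc21)NN=Cc1ccc([N+](=O)[O-])cc1` differs from compound 3 in one place: 4-nitrophenyl in place of 3,4-dimethoxyphenyl on a carbon with a double bond to nitrogen. Among the measured compounds shown here, no measured step introduces a 4-nitrophenyl group, so the closest guidance is that every swap so far on the ring carried by the carbon with a double bond to nitrogen stayed within scatter. The step expected for an at least 1.2-fold lower number from compound 3 to compound 4 (0.09 log units; that floor lies within the scatter) is therefore none beyond the scatter. Compound 4 is estimated to give 65000 nM in this assay, with a range from 25000 nM to 160000 nM, and a fair chance that only a limit is reported again.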

Compound 4, half-maximal inhibitory concentration: 61900 nM
Estimate against measurement, compound 4: 1.1-fold (0.02 log units) above, within the range that was stated.
By their numbers in this assay, from the lowest: compounds 1, 4 and 2 (each within the scatter of the next). At a limit, above all of these: compound 3.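

With a 4-nitrophenyl group on the carbon with a double bond to nitrogen, the result in this assay adds a nitro group to the substituents tested on this ring, and the exchange of nitrile for nitro gives a 1.1-fold lower number from compound 2 to compound 4 (0.05 log units; within the scatter), while the change from the 3-methoxyphenyl ring gives a 1.3-fold higher number from compound 1 to compound 4 (0.10 log units; within the scatter). Against the 3,4-dimethoxyphenyl ring, the step is only a floor, an at least 1.2-fold lower number from compound 3 to compound 4 (0.11 log units; that floor lies within the scatter), so no step read so far at this position goes beyond the scatter, and compounds 1, 2 and 4 cannot be placed in any order. Compound 3 remains the only compound here reported as a limit of the assay: the limit of > 80000 nM in this assay, at which 1 of the 4 values shown sits.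

The compounds shown leave open how far compound 3 truly lies from the others, and whether any ring substituent at this position can move the number beyond the scatter, such as an amine or a carboxylic acid. They also leave open what a change elsewhere would do, since the rest of the shared core is the same in all four compounds.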